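A few compounds are considered here, and "the series" means these few. Any claim that something is new, unique, unknown or untested is made for them only; others in the source may bear on it.

In a functional assay on EKVX cells (Homo sapiens) for cytotoxicity, read by sulforhodamine B assay, with a stated time of 48 h, tested at 100 nM (on this read-out lower numbers stand for a stronger effect and higher numbers for a weaker effect at the one concentration tested), compound 1 `COc1cc(C)cc(-c2c(-c3ccnc(-c4ccc(C(C)=O)cc4)c3)cnn2CC#N)c1` gives 91%, a weak effect at the one concentration tested. Compound 2 `COc1cc(C)cc(-c2nn(CC#N)cc2-c2ccc(-c3cccc(C(C)=O)c3)nc2)c1` gives 89%, and the two numbers lie within the usual scatter of each other, so nothing separates them. Compound 3 `COc1cc(C)cc(-c2c(-c3ccnc(-c4ccc(N(C)C)cc4)c3)cnn2CC#N)c1` has not yet been measured in this assay; it differs from compound 1 by dimethylamino in place of acetyl on an aromatic carbon. Among the compounds with values here, no measured pair shows this change, so there is no step to lean on. Compound 3 is expected to stay close, with an expected step of a number 6 percentage points lower from compound 1 to compound 3 (within the scatter), not beyond the scatter. The estimate for compound 3 is 85%, between 60% and 102%.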

Compound 3, a percentage reported as activity, at one concentration (the size of the read-out at that concentration, not a potency): 14%
For compound 3 the middle estimate is 71 percentage points above the measured one; the whole stated range lies above it.
By their numbers in this assay, from the lowest: compound 3; then compounds 2 and 1 (each within the scatter of the next).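

Putting dimethylamino in place of acetyl gives a number 77 percentage points lower from compound 1 to compound 3 (beyond the scatter) in this assay, so the group on this aromatic carbon, para to a large group, can strongly change the effect at the one concentration tested. The two groups have the same number of heavy atoms and of hydrogen-bond acceptors, so neither count separates them. No measurement available here accounts for the step.

Going by these compounds, it remains open whether a primary amine, a methoxy group or a morpholine at this place would act like dimethylamino. Also open, on these data alone, is whether the stronger effect of compound 3 at the one concentration tested would hold at other concentrations, since a single concentration cannot show that.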